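Swapping the aryl group on a shared core: predicting half-life

The source may hold more compounds than are shown below. What is called first, only, known or untested is meant among the compounds shown, and "the series" means these compounds.

Of the compounds shown here, three built on one shared core have been measured in an ADME assay (liver) for metabolic stability, with Liver microsome (Homo sapiens) as the target, read by LC-MS, using microsomes, tested at 1 uM; a higher number here means that the compound lasts longer, a lower number that the compound disappears faster. Compound 2 `CNc1nc(NCCCN(C)C)c2sc(-c3ccc(OC)nc3)cc2n1` gives 3.02 h, the highest of the three numbers. Compound 1 `CNc1nc(NCCCN(C)C)c2sc(-c3ccc(C(F)(F)F)cc3)cc2n1` gives 2.07 h, which lies within the scatter of compound 2. Compound 3 `CNc1nc(NCCCN(C)C)c2sc(-c3ccc(N4CCNCC4)cc3)cc2n1` gives 0.8 h, and the gap to compound 2 is beyond the scatter.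

Within the data shown here, the only single-point step among the measured compounds is a 2.6-fold lower number from compound 1 to compound 3 (0.41 log units; beyond the scatter). It shows that exchanging the group on the aromatic carbon of the five-membered ring, next to the ring sulfur, can move the half-life by a modest amount.

Compound 4 `CNc1nc(NCCCN(C)C)c2sc(-c3cncnc3)cc2n1` differs from compound 2 by pyrimidin-5-yl in place of 6-methoxypyridin-3-yl on an aromatic carbon. Among the measured compounds shown here, no measured pair carries this exact exchange, so the step from compound 1 to compound 3 is the only guide, and it suggests a change no larger than modest, if any. Compound 4 is expected to give 2 h, with a range from 0.9 h to 4.5 h. This estimate means an expected step of a 1.5-fold lower number from compound 2 to compound 4 (0.18 log units; within the scatter), probably not beyond the scatter.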

Compound 4, half-life: > 1.66 h
Compound 4: no number, only a limit; the forecaster's own chance of this, stated with the estimate: 5%; the middle value does not contradict the limit.
By their numbers in this assay, from the lowest: compound 3; then compounds 1 and 2 (each within the scatter of the next).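

In this assay compound 4 gives > 1.66 h, which is a limit and not a number, so no step can be read from compound 2 to compound 4. The compounds shown leave open whether pyrimidin-5-yl in place of 6-methoxypyridin-3-yl changes the half-life at all, and in which direction.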